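Methoxy in Place of Methylsulfonyl on a Shared Core

This account rests on a few compounds, and the source may have more. Where it says the series, first, only, none or still open, it means among the compounds named here.

Compound 1, `N#Cc1ccc(-c2nc(N)c3cc(CN4CCC(F)CC4)sc3n2)cc1`: 8430 nM
Compound 2, `CS(=O)(=O)c1cccc(-c2nc(N)c3cc(CN4CCC(F)CC4)sc3n2)c1`: > 10000 nM

Of the compounds shown here, two sharing one core have been measured in an assay on CHO-K1 cells for antagonist activity at adenosine receptor A1 (Homo sapiens), read by a beta-galactosidase reporter, with stated times of 15 min and 6 h; a higher number here means a weaker inhibitor, a lower number a stronger inhibitor. Compound 1 gives 8430 nM in this assay. For compound 2 only a limit is known: compound 2 gives > 10000 nM, which is the limit of this assay rather than a number. Compound 2 therefore stands at the weak end of what this assay can report, as shown by the limit of > 10000 nM in this assay, at which 1 of the 2 values shown sits.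

Compound 3, `COc1cccc(-c2nc(N)c3cc(CN4CCC(F)CC4)sc3n2)c1`, has not yet been measured. It differs from compound 2 by methoxy in place of methylsulfonyl on an aromatic carbon. For the measured compounds named here, compound 2 is known only as a limit, so no measured step shows how large a change of this kind should be. The step from compound 2 to compound 3 is estimated as an at least 1.6-fold lower number from compound 2 to compound 3 (0.22 log units; that floor lies within the scatter), a move toward a stronger inhibitor that may not reach beyond the scatter. Compound 3 is expected to give 6000 nM, between 2000 nM and 20000 nM.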

Compound 3, inhibition constant: 3220 nM
Beside the measured number, compound 3's estimate is 1.9-fold (0.27 log units) above it, within the range that was stated.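

Compound 3 shows that this aromatic carbon responds to the group it carries: in this assay, methoxy in place of methylsulfonyl gives an at least 3.1-fold lower number from compound 2 to compound 3 (0.49 log units; beyond the scatter), a move toward a stronger inhibitor. The same compound also reads against compound 1, where 3-methoxyphenyl in place of 4-cyanophenyl gives a 2.6-fold lower number from compound 1 to compound 3 (0.42 log units; beyond the scatter). The first of these steps is only a floor, because compound 2 is known only as a limit: the limit of > 10000 nM in this assay, at which 1 of the 3 values shown sits.

The compounds shown leave open how an amine, a carboxylic acid or a longer chain in place of methoxy would read at this position. They also leave open how a 4-methoxyphenyl group would read, which would help separate the effect of the group itself from that of its place on the ring.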